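Cytotoxicity on Vero cells across a shared nitroimidazooxazine core

The compounds below may be only part of what the source reports. "The series", "measured", "known", "first", "only" and "open" are said of these compounds alone.

Measured so far:
compound 1 `C[C@]1(CN2CCc3nc(-c4ccc(F)c(F)c4)oc3C2)Cn2cc([N+](=O)[O-])nc2O1`: > 32 ug/mL
compound 2 `C[C@]1(CN2CCc3sc(-c4ccc(F)cc4)nc3C2)Cn2cc([N+](=O)[O-])nc2O1`: "not determined" (no result reported)
compound 3 `C[C@]1(CN2CCc3nc(C(F)(F)F)ccc3C2)Cn2cc([N+](=O)[O-])nc2O1`: "not determined" (no result reported)

The three compounds share one core and differ in the group attached to the bicyclic amine. In an ADME assay on Vero cells (Chlorocebus sabaeus) for cytotoxicity, read by MTT assay, with a stated time of 72 h (a lower number here means that less compound is tolerated, a higher number that more compound is tolerated), compound 1 reaches only the limit > 32 ug/mL, and that value is a limit of the assay rather than a number. Compound 2 has no result in this assay. Among the measured compounds shown here, compound 3 likewise has no result in this assay, so it stands without a number of its own; the only value in view is the one at the limit of > 32 ug/mL in this assay, at which 1 of the 3 values shown sits.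

Compound 4 `C[C@]1(CN2CCc3nc(-c4cc(F)c(F)c(F)c4)ccc3C2)Cn2cc([N+](=O)[O-])nc2O1` is yet to be measured. It differs from compound 3 by 3,4,5-trifluorophenyl in place of trifluoromethyl on an aromatic carbon. For the measured compounds named here, with no measured step to lean on, no step beyond the scatter in this assay is expected in either direction, and the single value in view sits at the limit. Compound 4 is therefore expected to give 32 ug/mL in this assay, in the range 16 ug/mL to 64 ug/mL.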

Compound 4, half-maximal cytotoxic concentration: > 32 ug/mL
Compound 4 ended at the assay's limit; the forecaster's own chance of this, stated with the estimate: 75%; the middle value sits exactly at the limit.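

In this assay compound 4 gives > 32 ug/mL, which is a limit and not a number. No step can be read between compound 3 and compound 4: compound 3 has no result. The compounds shown leave open what 3,4,5-trifluorophenyl in place of trifluoromethyl does to tolerance in this assay.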